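Adding a second methoxy group to compound 3

A few compounds are considered here, and "the series" means these few. Any claim that something is new, unique, unknown or untested is made for them only; others in the source may bear on it.

Measured in an ADME assay on Vero cells (Chlorocebus sabaeus) for cytotoxicity, read by MTT assay, with a stated time of 96 h; a lower number here means that less compound is tolerated, a higher number that more compound is tolerated:
- compound 1 `COc1ccc(-c2nc3cc(C(C)=O)ccc3[nH]2)c(OC)c1`: > 100000 nM (a limit)
- compound 2 `CC(=O)c1ccc2c(c1)nc(-c1ccc(Cl)cc1)n2C1CCCCC1`: > 100000 nM (a limit)
- compound 3 `COc1ccc(-c2nc3cc(C(C)=O)ccc3n2C2CCCCC2)cc1`: 30000 nM

Going by the values given here, compound 3 gives 30000 nM, the only actual number so far. Compound 1 and compound 2 stand at the limit of > 100000 nM in this assay, at which 2 of the 3 values shown sit.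

Compound 4 `COc1ccc(-c2nc3cc(C(C)=O)ccc3n2C2CCCCC2)c(OC)c1` differs from compound 3 in one place: methoxy in place of hydrogen on an aromatic carbon. This is methoxy in place of hydrogen on an aromatic carbon, ortho to a large group and meta to a methoxy group.

Among the compounds with values here, only one measured step is available, an at least 3.3-fold lower number from compound 2 to compound 3 (0.52 log units; beyond the scatter). It is methoxy in place of chloro on an aromatic carbon, so it is a different exchange and bears on the new change only loosely. It does show that a single exchange on this aromatic ring can move the number beyond the scatter. Compound 4 shares its two methoxy groups with compound 1. Within the data shown here, the value of compound 1, > 100000 nM, is a limit and gives no size of step.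

No firm direction follows from these data, so no change beyond the scatter is expected in this assay, with a slight lean towards a higher number. The estimate is a 1.3-fold higher number from compound 3 to compound 4 (0.10 log units; within the scatter). The expected value for compound 4 is 38000 nM, within an estimated range of 15000 nM to 100000 nM.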

Compound 4, half-maximal cytotoxic concentration: 70000 nM
Compound 4: middle estimate off by 1.8-fold (0.27 log units), on the low side; measured number inside the range.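

In this assay, methoxy in place of hydrogen on an aromatic carbon, ortho to a large group and meta to a methoxy group, gives a 2.3-fold higher number from compound 3 to compound 4 (0.37 log units; beyond the scatter), so this position can move the number beyond the scatter, towards more compound tolerated. Going by these compounds alone, the only earlier measured exchange on this aromatic ring, methoxy in place of chloro, ran the other way, with an at least 3.3-fold lower number from compound 2 to compound 3 (0.52 log units; beyond the scatter), so the two exchanges on this ring do not share a direction. Cyclohexyl in place of hydrogen on an aromatic nitrogen gives an at least 1.4-fold lower number from compound 1 to compound 4 (0.15 log units; that floor lies within the scatter), which fixes no size for that exchange, and the reading stops at the top of the measurable range: the limit of > 100000 nM in this assay, at which 2 of the 4 values shown sit.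

The compounds shown leave open whether a hydroxyl, a fluorine or an ethoxy group at this same place would give a similar rise, or whether the step belongs to methoxy alone. Also open, as far as these compounds go, is whether the second methoxy group moves the number at all when the aromatic nitrogen carries hydrogen, a short alkyl chain or an amine-bearing chain in place of cyclohexyl.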